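Swapping the Carboxy Chain for Ethoxycarbonyl on the Amine Nitrogen

The compounds below may be only part of what the source reports. "The series", "measured", "known", "first", "only" and "open" are said of these compounds alone.

In a functional assay on MCF7 cells (Homo sapiens) for inhibition, read by MTT assay, with a stated time of 3 days (a higher number here means a weaker inhibitor, a lower number a stronger inhibitor), compound 1 (`CC[C@H](C)[C@H](NCC(=O)NNC(=O)COc1ccc(-c2nc3ccccc3s2)cc1OC)C(=O)O`) gives 1710 nM, compound 2 (`CC[C@H](C)[C@@H](NCC(=O)NNC(=O)COc1ccc(-c2nc3ccccc3s2)cc1OC)C(=O)O`) gives 1790 nM and compound 3 (`COc1cc(-c2nc3ccccc3s2)ccc1OCC(=O)NNC(=O)CN[C@@H](CCSC)C(=O)O`) gives 1950 nM. Compound 3 therefore stands level with the other two, within the scatter of both.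

Compound 4 (`CCOC(=O)[C@@H](NCC(=O)NNC(=O)COc1ccc(-c2nc3ccccc3s2)cc1OC)[C@@H](C)CC`) departs from compound 3 on an amine nitrogen, where 1-(ethoxycarbonyl)-2-methylbutyl takes the place of 1-carboxy-3-(methylsulfanyl)propyl: 1-(ethoxycarbonyl)-2-methylbutyl in place of 1-carboxy-3-(methylsulfanyl)propyl on an amine nitrogen.

For the measured compounds named here, three measured steps bear on this change. Given (the fact that compounds 1 and 2 differ only in the configuration as drawn), the change of configuration amounts to a 1.0-fold higher number from compound 1 to compound 2 (0.02 log units; within the scatter). The exchange of side chains amounts to a 1.1-fold higher number from compound 1 to compound 3 (0.06 log units; within the scatter), and seen from the other stereoisomer to a 1.1-fold higher number from compound 2 to compound 3 (0.04 log units; within the scatter). All three lie within the scatter, so neither configuration nor this exchange of chains has moved the number in this assay.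

On these data alone, none of these steps replaces 1-carboxy with ethoxycarbonyl, so that part of the change is untested and the range must stay wide. With only these flat steps to go on, no shift beyond the scatter is expected.

The expected change is a 1.1-fold lower number from compound 3 to compound 4 (0.03 log units; within the scatter). For compound 4 the estimated value is 1800 nM, with an expected range from 750 nM to 4300 nM.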

Compound 4, half-maximal inhibitory concentration: 1950 nM
Compound 4: middle estimate off by 1.1-fold (0.03 log units), on the low side, and the stated range covers the measured number.
By their numbers in this assay, from the lowest: compounds 1, 2, 3 and 4 (each within the scatter of the next).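

The step that tests the part left open is ethyl in place of hydrogen on an oxygen next to a carbonyl group, and in this assay it amounts to a 1.1-fold higher number from compound 1 to compound 4 (0.06 log units; within the scatter) for the ester and its free carboxy partner. The partner of opposite configuration gives the same reading, with 1-(ethoxycarbonyl)-2-methylbutyl in place of 1-carboxy-2-methylbutyl on the amine nitrogen amounting to a 1.1-fold higher number from compound 2 to compound 4 (0.04 log units; within the scatter) in the same assay. The whole exchange on that nitrogen, in which a chain with 1 hydrogen-bond donor and a sulfur gives way to one with 0 donors and no sulfur, amounts to no change at the digits printed from compound 3 to compound 4 (within the scatter) and so shows that, among these four compounds, this position tolerates the ester as well as the free carboxy group in this assay.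

On these data alone, whether the flat reading holds for a benzyl ester, a primary amide or a free amine at this carbon remains open, as the four compounds all carry a carboxy group or its ethyl ester there. Nothing available explains why the ethyl group leaves the number where it stands.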